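Moving the methyl group on the pyridin-2-yl ring

The source may hold more compounds than are shown below. What is called first, only, known or untested is meant among the compounds shown, and "the series" means these compounds.

Measured compounds:
compound 1 `O=C(CCCCCCc1ccccc1)c1ncc(-c2ccc(O)cc2)o1` — 140 nM
compound 2 `Cc1cccnc1-c1cnc(C(=O)CCCCCCc2ccccc2)o1` — 15 nM

Within the data shown here, in an assay (Rattus norvegicus) for inhibition of Fatty-acid amide hydrolase 1 (Homo sapiens) (a higher number here means a weaker inhibitor, a lower number a stronger inhibitor), compound 2 holds the lowest of the two numbers, the only measured step being a 9.3-fold lower number from compound 1 to compound 2 (0.97 log units; beyond the scatter). Compound 3 `Cc1ccnc(-c2cnc(C(=O)CCCCCCc3ccccc3)o2)c1` keeps the same atoms: 4-methylpyridin-2-yl in place of 3-methylpyridin-2-yl on an aromatic carbon. Among the measured compounds shown here, no measured step moves the methyl group within the pyridin-2-yl ring; the one step on record swaps the whole aryl group. Since that step leaves the position of the methyl untested, no step beyond the scatter is expected, so compound 3 is estimated at 15 nM (range 5 nM to 45 nM), an expected step of no change at the digits printed from compound 2 to compound 3 (within the scatter).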

Compound 3, inhibition constant: 0.6 nM
Beside the measured number, compound 3's estimate is 25-fold (1.40 log units) above it, outside the stated range (below it).
By their numbers in this assay, from the lowest: compound 3; then compound 2; then compound 1.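

Within this assay, the position of the methyl on the pyridin-2-yl ring matters on its own: with the atoms unchanged, the move gives a 25-fold lower number from compound 2 to compound 3 (1.40 log units; beyond the scatter). Against the 4-hydroxyphenyl group on this aromatic carbon, 4-methylpyridin-2-yl gives a 230-fold lower number from compound 1 to compound 3 (2.37 log units; beyond the scatter), so the earlier aryl swap did not show the full reach of this position. Nothing on hand accounts for the effect of moving the methyl.

Still open, from the compounds shown here alone, is whether a methoxy group, an amine or a carboxylic acid in place of the methyl on 4-methylpyridin-2-yl would keep this gain. Also open, going by these compounds, is how a shorter or longer chain on the carbonyl would behave with this aryl group.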